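A few compounds are considered here, and "the series" means these few. Any claim that something is new, unique, unknown or untested is made for them only; others in the source may bear on it.

Among the measured compounds shown here, in a functional assay on MC-38 cells (Mus musculus) for antiproliferative activity, read by CCK-8 assay, with a stated time of 48 h (on this read-out lower numbers stand for stronger inhibition and higher numbers for weaker inhibition), compound 2 (`COc1ccc(/C=C\c2cc(OC)c(OC)c(OC)c2)cc1OCc1ccc(C=O)cc1`) gives 900 nM, the only actual number so far. Compound 1 (`COc1ccc(/C=C\c2cc(OC)c(OC)c(OC)c2)cc1OCc1ccc(CNC(C)(C)C(=O)O)cc1`) reads > 10000 nM, which is a limit. Compound 3 (`COc1ccc(/C=C\c2cc(OC)c(OC)c(OC)c2)cc1OCc1ccc(CN2C[C@H](O)C[C@@H]2C(=O)O)cc1`) differs from compound 2 at one place: (2-carboxy-4-hydroxypyrrolidin-1-yl)methyl in place of formyl on an aromatic carbon, para to a large group. For the measured compounds named here, the one measured step bearing on this is an at least 11-fold lower number from compound 1 to compound 2 (1.04 log units; beyond the scatter), large and beyond the scatter, with formyl on the side of the lower number and a carboxy-bearing amine group on the other, so a large step to a higher number in this assay is expected on going to compound 3. The expected change is a 10-fold higher number from compound 2 to compound 3 (1.00 log units; beyond the scatter). For compound 3 the estimated value is 9000 nM, with an expected range of 2500 nM to 30000 nM.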

Compound 3, half-maximal inhibitory concentration: > 10000 nM
Compound 3: a limit, no number; the forecaster's own chance of this, stated with the estimate: 55%; at least 1.1-fold (0.04 log units) between middle value and limit.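

In this assay, a second carboxy-bearing amine group at this place, now with the nitrogen inside a five-membered non-aromatic ring, again separates sharply from formyl, an at least 11-fold higher number from compound 2 to compound 3 (1.04 log units; beyond the scatter), so the drop is not tied to the open-chain (1-carboxy-1-methylethyl)amino group of compound 1. Compound 3 gives > 10000 nM, which is a limit and not a number. The step between compound 1 and compound 3 cannot be read, and the two carboxy-bearing groups cannot be ranked against each other: the limit of > 10000 nM in this assay, at which 2 of the 3 values shown sit.

The compounds shown do not separate the part of the amine from that of the carboxylic acid, since both enter together in compound 1 and compound 3. From the compounds shown here alone, a methyl ester of the same carboxylic acid, or a dimethylaminomethyl group on the same aromatic carbon, remains open as a way of telling the two apart.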